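The source may hold more compounds than are shown below. What is called first, only, known or untested is meant among the compounds shown, and "the series" means these compounds.

Three compounds share one core. Compound 1 `CC(=O)C(=O)Nc1ccc2nc(NC(=O)c3cc4ccccc4[nH]3)sc2c1`, compound 2 `CCOC(=O)C(=O)Nc1ccc2nc(NC(=O)c3cc4cc(CC)ccc4[nH]3)sc2c1` and compound 3 `CCOC(=O)C(=O)Nc1ccc2nc(NC(=O)c3ncccn3)sc2c1` were examined in a functional assay on MCF7 cells (Homo sapiens) for antiproliferative activity; a lower number here means that less compound is needed, a higher number that more compound is needed for the effect. For compound 1 only a limit is reported, > 50000 nM. Compound 2 gives 25300 nM. For compound 3 the result is likewise a limit, > 50000 nM. Compound 3 thus stands where no number is known, and (the limit of > 50000 nM in this assay, at which 2 of the 3 values shown sit). Compound 4 `CCOC(=O)C(=O)Nc1ccc2nc(NC(=O)c3cc4ccccc4[nH]3)sc2c1` has not yet been measured; it differs from compound 3 in one place: 1H-indol-2-yl in place of pyrimidin-2-yl on a carbonyl carbon. Among the measured compounds shown here, no measured pair isolates this exchange, so its effect is open. Compound 4 is expected to remain weak, with an expected step of an at least 1.4-fold lower number from compound 3 to compound 4 (0.15 log units; that floor lies within the scatter). The estimate for compound 4 is 35000 nM, ranging from 12000 nM to 100000 nM.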

Compound 4, half-maximal effective concentration: 8990 nM
The estimate for compound 4 lay 3.9-fold (0.59 log units) above the measured number; the whole stated range lies above it.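

In this assay, 1H-indol-2-yl in place of pyrimidin-2-yl on a carbonyl carbon gives an at least 5.5-fold lower number from compound 3 to compound 4 (0.74 log units; beyond the scatter), so this position responds to the exchange. Ethoxy in place of methyl on a carbonyl carbon gives an at least 5.5-fold lower number from compound 1 to compound 4 (0.74 log units; beyond the scatter), while hydrogen in place of ethyl on an aromatic carbon gives a 2.8-fold lower number from compound 2 to compound 4 (0.45 log units; beyond the scatter), so the ethyl group of compound 2 is not needed for this effect. The results for compound 1 and compound 3 are limits, so those two steps give only a floor: the limit of > 50000 nM in this assay, at which 2 of the 4 values shown sit.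

Going by these compounds, whether an amine or a carboxylic acid in place of ethoxy would preserve the effect remains open.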